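This account rests on a few compounds, and the source may have more. Where it says the series, first, only, none or still open, it means among the compounds named here.

Measured compounds in a functional assay on A-375 cells (Homo sapiens) for antiproliferative activity, read by CCK-8 assay, with a stated time of 72 h, tested at 2 uM; on this read-out higher numbers stand for a stronger effect at the one concentration tested and lower numbers for a weaker effect:
compound 1, `CN(Cc1cccnc1)C(=S)SCc1ccc(C(=O)Nc2ccccc2N)cc1`, gives 39.4%
compound 2, `Nc1ccccc1NC(=O)c1ccc(CSC(=S)N2CCN(c3ccncc3)CC2)cc1`, gives 85.7%
compound 3, `Nc1ccccc1NC(=O)c1ccc(CSC(=S)N(Cc2ccccc2)Cc2ccccc2)cc1`, gives 10.9%

Compound 2 stands highest of the three numbers in this assay. Compound 1 is the nearest to it, with a number well below it, beyond the scatter, and compound 3 is the furthest, again beyond the scatter. All three share a core that differs only in the groups on the nitrogen of the dithiocarbamate, and compound 2, the one carrying a six-membered non-aromatic ring with two nitrogens, sits well apart from the two open-chain analogues.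

Compound 4, `Cc1ccc(N2CCN(C(=S)SCc3ccc(C(=O)Nc4ccccc4N)cc3)CC2)cc1`, is not yet measured. It differs from compound 2 in one place: 4-methylphenyl in place of pyridin-4-yl on an amine nitrogen in a ring. Going by the values given here, no step between measured compounds mirrors this change, so the expectation rests on compound 2 alone. The six-membered ring with two nitrogens is kept, and the group on its nitrogen remains a single aromatic ring, so a change of moderate size, downward, is expected in this assay, though a result within the scatter cannot be excluded. Compound 4 is estimated at 62%, with a range from 30% to 88%, which means an expected step of a number 23.7 percentage points lower from compound 2 to compound 4 (beyond the scatter).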

Compound 4, a percentage reported as inhibition, at one concentration (the size of the read-out at that concentration, not a potency): 25.8%
Compound 4: middle estimate off by 36.2 percentage points, on the high side, and the stated range ends above it.
By their numbers in this assay, from the lowest: compound 3; then compound 4; then compound 1; then compound 2.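

In this assay, the swap of pyridin-4-yl for 4-methylphenyl on the amine nitrogen in the ring gives a number 59.9 percentage points lower from compound 2 to compound 4 (beyond the scatter) and so shows that this position is sensitive to which aromatic ring it carries: keeping the six-membered non-aromatic ring with two nitrogens does not by itself keep the effect. Going by these compounds alone, the single step removes the ring nitrogen and brings in a methyl group together, so it cannot show which of these two differences matters. Nothing measured here accounts for the size of the step.

On these data alone, it remains open whether a plain phenyl group on the same nitrogen would read like compound 2 or like compound 4. As far as these compounds go, it is equally open how pyridin-3-yl or pyridin-2-yl would compare with the pyridin-4-yl of compound 2.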